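Swapping cyano for nitro on a second, related core

The source may report more compounds than this note shows. Statements on the series, on what has been measured and on what is new or still open speak of the compounds shown alone.

Compound 1 `N#Cc1ccc2c(c1)C(N1CCCCC1=O)=CC(CF)(CF)O2` and compound 2 `O=C1CCCCN1C1=CC(CF)(CF)Oc2ccc([N+](=O)[O-])cc21` share one core, and in a functional assay (aorta) with Rattus norvegicus as the target (on this read-out higher numbers stand for an effect only at larger amounts of compound and lower numbers for an effect already at smaller amounts), compound 1 gives 162 nM while compound 2 gives 17.4 nM. The change between them, (nitro in place of cyano on an aromatic carbon), produced a 9.3-fold lower number from compound 1 to compound 2 (0.97 log units; beyond the scatter). Compound 3 `N#Cc1ccc2c(c1)[C@@H](n1ccccc1=O)[C@H](O)C(CF)(CF)O2` has a different core; the difference between the two cores is not broken down here. In this assay compound 3 gives 148 nM, close to compound 1. Compound 4 `O=c1ccccn1[C@@H]1c2cc([N+](=O)[O-])ccc2OC(CF)(CF)[C@H]1O` carries the same change relative to compound 3, (nitro in place of cyano on an aromatic carbon), at the same place on the ring. Because the earlier step gave a 9.3-fold lower number from compound 1 to compound 2 (0.97 log units; beyond the scatter), a step of similar size, a 7.4-fold lower number from compound 3 to compound 4 (0.87 log units; beyond the scatter), is expected here, slightly widened for the change of core. Compound 4 is therefore estimated at 20 nM, between 7 nM and 60 nM.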

Compound 4, half-maximal effective concentration: 28.8 nM
Estimate against measurement, compound 4: 1.4-fold (0.16 log units) below; the measured number falls inside the stated range.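

Swapping cyano for nitro on the aromatic carbon gives a 5.1-fold lower number from compound 3 to compound 4 (0.71 log units; beyond the scatter) in this assay, so the change points the same way on the second core as on the first. The two steps also agree in size: the same change on two cores in this assay, a 9.3-fold lower number (0.97 log units; beyond the scatter) from compound 1 to compound 2 and a 5.1-fold lower number (0.71 log units; beyond the scatter) from compound 3 to compound 4, 1.8-fold (0.26 log units) apart, within the scatter of two such steps. This shows that the change carried over between these two cores, but two pairs do not make a general rule, and the numbers do not explain why nitro gives the lower number.

Still open, from the compounds shown here alone, is whether the step would hold on a third core. Going by these compounds, it is also open how a different group on that aromatic carbon, such as an amine or a carboxylic acid, would compare with nitro and cyano.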